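The source may hold more compounds than are shown below. What is called first, only, known or untested is meant among the compounds shown, and "the series" means these compounds.

Among the compounds with values here, in a functional assay on MDA-MB-231 cells (Homo sapiens) for inhibition, read by sulforhodamine B assay, tested at 10 uM (on this read-out lower numbers stand for less inhibition and higher numbers for more inhibition at the one concentration tested (going by the name of the read-out)), compound 1 `CN1CCN(c2ccc(C3=NN(C(=O)c4ccc(C(F)(F)F)cc4)C(c4ccc(N(C)C)cc4)C3)cc2)CC1` gives 55.4%, the highest of the two numbers measured so far. Compound 2 `CN1CCN(c2ccc(C3=NN(S(C)(=O)=O)C(c4ccc(N(C)C)cc4)C3)cc2)CC1` gives 0.6% in this assay. Within the data shown here, the only measured step, a number 54.8 percentage points lower from compound 1 to compound 2 (beyond the scatter), concerns the amine nitrogen in the ring. Compound 3 `CN(C)c1ccc(C2CC(c3ccc(-n4cncn4)cc3)=NN2C(=O)c2ccc(C(F)(F)F)cc2)cc1` differs from compound 1 by 1H-1,2,4-triazol-1-yl in place of 4-methylpiperazin-1-yl on an aromatic carbon. That measured step does not bear on this change, and compound 3 keeps the (4-(trifluoromethyl)phenyl)carbonyl group of compound 1, so only a modest fall is expected, a number 15.4 percentage points lower from compound 1 to compound 3 (beyond the scatter). Compound 3 is estimated at 40%, within a range from 10% to 70%.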

Compound 3, a percentage reported as inhibition, at one concentration (the size of the read-out at that concentration, not a potency): 16.7%
Compound 3: the middle estimate sits 23.3 percentage points above what was measured; the range from low to high includes it.
By their numbers in this assay, from the lowest: compound 2; then compound 3; then compound 1.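

Replacing 4-methylpiperazin-1-yl with 1H-1,2,4-triazol-1-yl gives a number 38.7 percentage points lower from compound 1 to compound 3 (beyond the scatter) in this assay. The group on this aromatic carbon therefore also weighs heavily on the read-out, even with the (4-(trifluoromethyl)phenyl)carbonyl group kept, a position the earlier step did not probe. Nothing available explains this step. From the compounds shown here alone, it remains open whether a morpholine ring or an open-chain amine such as dimethylamino at this position would keep the number near that of compound 1. Going by these compounds, it is also open whether this change would have any comparable effect alongside the methylsulfonyl group.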